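The source may hold more compounds than are shown below. What is called first, only, known or untested is meant among the compounds shown, and "the series" means these compounds.

Measured in a functional assay on M21 cells (Homo sapiens) for antiproliferative activity, read by sulforhodamine B assay, with a stated time of 48 h; on this read-out higher numbers stand for weaker inhibition and lower numbers for stronger inhibition:
- Compound 1 `Cc1cccc(NS(=O)(=O)c2ccc(N3CCNC3=O)cc2)c1`: 69 nM
- Compound 2 `Cc1cccc(NS(=O)(=O)c2ccc(N3CCNC3=O)cc2)c1C`: 110 nM
- Compound 3 `O=C1NCCN1c1ccc(S(=O)(=O)Nc2cccc(Cl)c2)cc1`: 25 nM

Compound 3 gives the lowest number of the three, which makes it the strongest inhibitor in this small set. Compound 4 `COc1ccccc1NS(=O)(=O)c1ccc(N2CCNC2=O)cc1` keeps the shared core but carries 2-methoxyphenyl in place of 3-chlorophenyl on a sulfonamide nitrogen.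

For the measured compounds named here, no measured compound carries a methoxy group, so no step tests this change directly. The nearest guides are the two steps that arrive at the 3-chlorophenyl group: a 2.8-fold lower number from compound 1 to compound 3 (0.44 log units; beyond the scatter) and a 4.4-fold lower number from compound 2 to compound 3 (0.64 log units; beyond the scatter). Both are modest, and both show the other aryl groups giving higher numbers. The step of a 1.6-fold higher number from compound 1 to compound 2 (0.20 log units; within the scatter) shows that adding a methyl group made no clear difference.

Replacing the 3-chlorophenyl group is therefore expected to raise the number in this assay modestly, though the direction remains uncertain. The expected change is a 3.2-fold higher number from compound 3 to compound 4 (0.51 log units; beyond the scatter). For compound 4 the estimated value is 80 nM, with an expected range from 20 nM to 300 nM.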

Compound 4, half-maximal inhibitory concentration: 300 nM
Compound 4: middle estimate off by 3.8-fold (0.57 log units), on the low side, within the range that was stated.
By their numbers in this assay, from the lowest: compound 3; then compounds 1 and 2 (each within the scatter of the next); then compound 4.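

In this assay, 2-methoxyphenyl on the sulfonamide nitrogen gives the highest number in the set, with a 12-fold higher number from compound 3 to compound 4 (1.08 log units; beyond the scatter), a 2.7-fold higher number from compound 2 to compound 4 (0.44 log units; beyond the scatter) and a 4.3-fold higher number from compound 1 to compound 4 (0.64 log units; beyond the scatter), so compound 4 is the weakest inhibitor of the four. The earlier compounds shown here showed that changing this aryl group could shift the number modestly, at most a 4.4-fold lower number from compound 2 to compound 3 (0.64 log units; beyond the scatter), whereas the step to compound 4 is large and shows that this position is more sensitive to the choice of group than they suggested. No measurement at hand explains why this exchange costs so much activity.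

The compounds shown leave open whether the rise follows the methoxy group itself or its place on the ring, a question that 3-methoxyphenyl and 2-chlorophenyl groups could separate. Going by these compounds, how an aryl group bearing an amine or a carboxylic acid would behave here also remains unknown.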